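A few compounds are considered here, and "the series" means these few. Any claim that something is new, unique, unknown or untested is made for them only; others in the source may bear on it.

In a functional assay on HT-29 cells (Homo sapiens) for antiproliferative activity, read by sulforhodamine B assay, with a stated time of 72 h (a lower number here means a stronger inhibitor, a higher number a weaker inhibitor), compound 1 (`S=C(N/N=C/c1ccc2ccccc2n1)Nc1ccccc1Br`) reads > 100000 nM, which is a limit of the assay and not a number. For the measured compounds named here, compound 2 (`S=C(N/N=C/c1ccc2ccccc2n1)Nc1ccc(Br)cc1`) gives 54400 nM, the only true number so far. Compound 3 (`COc1ccc(NC(=S)N/N=C/c2ccc3ccccc3n2)cc1`) carries methoxy in place of bromo on an aromatic carbon, para to a large group: methoxy in place of bromo on an aromatic carbon. Going by the values given here, the single measured step, an at least 1.8-fold lower number from compound 1 to compound 2 (0.26 log units; that floor lies within the scatter), swaps 2-bromophenyl for 4-bromophenyl, and its floor lies within the scatter. It never replaces the bromo itself, so it gives no direction here. The expected change, a 1.1-fold lower number from compound 2 to compound 3 (0.04 log units; within the scatter), is therefore none beyond the scatter. For compound 3 the estimated value is 50000 nM, with an expected range of 15000 nM to 100000 nM.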

Compound 3, half-maximal inhibitory concentration: 82300 nM
For compound 3 the middle estimate is 1.6-fold (0.22 log units) below the measured one; measured number inside the range.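

In this assay, methoxy in place of bromo on an aromatic carbon, para to a large group, gives a 1.5-fold higher number from compound 2 to compound 3 (0.18 log units; within the scatter). This is the first step that replaces the bromo itself, and even with the hydrogen-bond acceptor that methoxy brings, the change stays within the scatter. 4-Methoxyphenyl in place of 2-bromophenyl gives an at least 1.2-fold lower number from compound 1 to compound 3 (0.08 log units; that floor lies within the scatter), which is only a floor, since the value for compound 1 is a limit of the assay and not a number: the limit of > 100000 nM in this assay, at which 1 of the 3 values shown sits.

Going by these compounds, whether an amine, a carboxylic acid or a longer chain at this position would move the number beyond the scatter remains open.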